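Clearance of compound 3: neopentyl on the ring amine

A few compounds are considered here, and "the series" means these few. Any claim that something is new, unique, unknown or untested is made for them only; others in the source may bear on it.

Compound 1 `Cc1ccc(S(=O)(=O)N2C=CNC(=O)[C@H]2CC(=O)NC2CCOCC2(C)C)cc1` gives < 100 mL.min-1.g-1 in an in vitro ADME assay on microsomes from liver (Homo sapiens) for pharmacokinetics (on this read-out higher numbers stand for fast clearance and lower numbers for slow clearance), and this is a limit. Compound 2 `Cc1ccc(S(=O)(=O)N2C=CNC(=O)[C@H]2CC(=O)N[C@H]2CCN(C)CC2(C)C)cc1` gives < 14 mL.min-1.g-1 in this assay, and this too is a limit, so compound 2 stands without a readable number. Among the compounds with values here, the only measured step, a step that the two limits leave unreadable from compound 1 to compound 2, has no size that can carry over. Compound 3 `Cc1ccc(S(=O)(=O)N2C=CNC(=O)[C@H]2CC(=O)N[C@H]2CCN(CC(C)(C)C)CC2(C)C)cc1` follows from compound 2 through (tert-butyl in place of hydrogen on a saturated chain carbon bound to an amine nitrogen in a ring). The same difference reads methyl to neopentyl, on an amine nitrogen in a ring. Within the data shown here, no measured step covers this change, so the expectation rests on the structural change alone and starts from the limit of compound 2 at < 14 mL.min-1.g-1. The expected step, toward faster clearance in this assay, is an at least 1.7-fold higher number from compound 2 to compound 3 (0.25 log units; that floor lies within the scatter). Compound 3 is estimated at 25 mL.min-1.g-1, with an expected range of 8 mL.min-1.g-1 to 70 mL.min-1.g-1.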

Compound 3, intrinsic clearance in microsomes: 405 mL.min-1.g-1
Beside the measured number, compound 3's estimate is 16-fold (1.21 log units) below it, and the stated range ends below it.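

On the amine nitrogen in the ring, methyl to neopentyl is the only change shown with a readable size: in this assay it gives an at least 28-fold higher number from compound 2 to compound 3 (1.46 log units; beyond the scatter). The group carried at this place can therefore move clearance in this read-out by far more than the scatter, while the step from compound 1 to compound 2 cannot be read. That size is a floor, since compound 2 is held only by a limit: the limit of < 14 mL.min-1.g-1 in this assay, at which 1 of the 3 values shown sits.

The compounds shown leave open how clearance runs through smaller groups such as ethyl or isopropyl on the amine nitrogen in the ring, and whether a straight butyl chain would give the same jump as neopentyl. Open too, as far as these compounds go, is what a hydroxyethyl group or a chain carrying a carboxylic acid would give at that place.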